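Hydroxy in place of hydrogen on the outer ring of compound 3

The compounds below may be only part of what the source reports. "The series", "measured", "known", "first", "only" and "open" are said of these compounds alone.

The three measured compounds share one core and differ only on the outer benzene ring: compound 1 `Cc1c(/N=C/c2ccc(N(C)C)cc2)c(=O)n(-c2ccccc2)n1C` carries a dimethylamino group there, compound 2 `COc1ccc(/C=N/c2c(C)n(C)n(-c3ccccc3)c2=O)cc1` a methoxy group, and compound 3 `Cc1c(/N=C/c2ccccc2)c(=O)n(-c2ccccc2)n1C` a hydrogen. In a functional assay on HCT-116 cells (Homo sapiens) for cytotoxicity, read by MTT assay, with a stated time of 72 h (a higher number here means a weaker inhibitor, a lower number a stronger inhibitor), compound 1 gives 832000000 nM. Compound 2 gives 575000000 nM in this assay, and compound 3 gives 589000000 nM in this assay. Compound 3 stands second highest of the three numbers, with compound 2 nearest and compound 1 furthest, and all three numbers lie within the scatter of one another. The steps of a 1.4-fold lower number from compound 1 to compound 3 (0.15 log units; within the scatter), a 1.0-fold higher number from compound 2 to compound 3 (0.01 log units; within the scatter) and a 1.4-fold lower number from compound 1 to compound 2 (0.16 log units; within the scatter) are each within the scatter.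

Compound 4 `Cc1c(/N=C/c2ccc(O)cc2)c(=O)n(-c2ccccc2)n1C` is compound 3 with hydroxy in place of hydrogen on an aromatic carbon. All three measured steps exchange a group on this same aromatic carbon, and none of them moves the number in this assay beyond the scatter, so the hydroxy group is expected to behave likewise. The step from compound 3 to compound 4 is therefore expected to be a 1.0-fold higher number from compound 3 to compound 4 (0.01 log units; within the scatter), that is, none beyond the scatter. Compound 4 is estimated at 600000000 nM in this assay, with a range from 300000000 nM to 1200000000 nM.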

Compound 4, half-maximal inhibitory concentration: 646000000 nM
The estimate for compound 4 lay 1.1-fold (0.03 log units) below the measured number; low and high end bracket the measured number.
By their numbers in this assay, from the lowest: compounds 2, 3, 4 and 1 (each within the scatter of the next).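

In this assay, the change from phenyl to 4-hydroxyphenyl, on an aromatic carbon para to a large group, gives a 1.1-fold higher number from compound 3 to compound 4 (0.04 log units; within the scatter), so the first hydrogen-bond donor in the series at this position leaves the number within the scatter. The two other new steps read the same way: hydrogen in place of the methyl on the oxygen gives a 1.1-fold higher number from compound 2 to compound 4 (0.05 log units; within the scatter), and hydroxy in place of dimethylamino gives a 1.3-fold lower number from compound 1 to compound 4 (0.11 log units; within the scatter). Dimethylamino, methoxy, hydroxy and hydrogen at this position therefore cannot be told apart in this assay, and the series now includes a group with a hydrogen-bond donor as well as groups without one; no further data bear on why the number stays flat here.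

On these data alone, whether a carboxylic acid, a primary amine or a longer alkyl chain on this aromatic carbon would move the number beyond the scatter remains open. Also open, as far as these compounds go, is whether changes elsewhere on the shared core, rather than on this outer ring, would shift the number in this assay.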